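Adding a chloro group to compound 2: an expected step

The source may report more compounds than this note shows. Statements on the series, on what has been measured and on what is new or still open speak of the compounds shown alone.

Compound 1 `Cn1c(CN2CCC(c3ccc(Cl)cc3)CC2)nc2ccccc21` gives 63.1 nM in a functional assay on HEK293 cells for antagonist activity at D(4) dopamine receptor (Homo sapiens), read by FLIPR; on this read-out lower numbers stand for stronger inhibition and higher numbers for weaker inhibition.
Compound 2 `Cn1c(CN2CCN(c3ccc(C(F)(F)F)cn3)CC2)nc2ccccc21` gives 1000 nM in this assay.
Compound 3 `Cn1c(CN2CCN(c3ccccc3C(F)(F)F)CC2)nc2ccccc21` gives 631 nM in this assay.

Among these three numbers compound 2 stands highest, which means the weakest inhibition so far. Its nearest neighbour is compound 3, whose number lies within the usual scatter of compound 2, so the two cannot be told apart. Compound 1 lies far lower, well beyond the scatter, and is clearly the stronger inhibitor of the two.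

Compound 4 `Cn1c(CN2CCN(c3ncc(C(F)(F)F)cc3Cl)CC2)nc2ccccc21` is not yet measured. It differs from compound 2 in one place: chloro in place of hydrogen on an aromatic carbon. The chloro sits ortho to a large group, two atoms from the ring nitrogen and meta to a trifluoromethyl group. Going by the values given here, no measured pair shows the effect of this exact change, so the expectation rests only on the spread of the three values. The step from compound 2 to compound 4 is expected to be modest, at best a mild improvement, a 2.5-fold lower number from compound 2 to compound 4 (0.40 log units; beyond the scatter), and quite possibly within the scatter. Compound 4 is therefore estimated at 400 nM in this assay, with a range from 100 nM to 1600 nM.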

Compound 4, inhibition constant: 631 nM
Beside the measured number, compound 4's estimate is 1.6-fold (0.20 log units) below it; measured number inside the range.
By their numbers in this assay, from the lowest: compound 1; then compounds 3, 4 and 2 (each within the scatter of the next).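

Putting a chloro in place of hydrogen on this aromatic carbon, ortho to a large group and two atoms from the ring nitrogen, gives a 1.6-fold lower number from compound 2 to compound 4 (0.20 log units; within the scatter) in this assay and so cannot be told apart from no change. Going by these compounds alone, this is the first single-place step, and it shows that this one added chlorine atom, meta to a trifluoromethyl group, produces no shift that can be distinguished from repeat-to-repeat variation at this position. Nothing available here explains this result.

As far as these compounds go, whether a different group on the same aromatic carbon, such as a methoxy group, an amine or a nitrile, would move the number beyond the scatter remains open. Also open, from the compounds shown here alone, is whether the chloro would give the same result with a nitrile in place of the trifluoromethyl group.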